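Bulk on the ring amine: a third methyl

The source may report more compounds than this note shows. Statements on the series, on what has been measured and on what is new or still open speak of the compounds shown alone.

Measured so far:
- compound 1 `CCN1CCN(CCC(=O)Nc2nc3c(C)cccc3s2)CC1`: 543 nM
- compound 2 `Cc1cccc2sc(NC(=O)CCN3CCN(C(C)C)CC3)nc12`: 1300 nM

Going by the values given here, in an assay on membranes from brain for displacement of a labelled ligand from Sigma non-opioid intracellular receptor 1 (Cavia porcellus), read by scintillation counting, with a stated time of 120 min (on this read-out lower numbers stand for stronger inhibition and higher numbers for weaker inhibition), compound 2 gives 1300 nM, the higher of the two numbers known, so it is the weaker binder of the pair; its nearest neighbour, compound 1, gives 543 nM. Among the compounds with values here, the only known step, a 2.4-fold higher number from compound 1 to compound 2 (0.38 log units; beyond the scatter), shows that adding a methyl at this chain carbon cost binding by a modest but real amount. Compound 3 `Cc1cccc2sc(NC(=O)CCN3CCN(C(C)(C)C)CC3)nc12` carries the same move one step further: methyl in place of hydrogen on a saturated chain carbon bound to an amine nitrogen in a ring and two saturated chain carbons. Within the data shown here, only that one step bears on the question, and it points toward a further loss in this assay. Compound 3 is therefore expected to show a modest weakening, a 2.2-fold higher number from compound 2 to compound 3 (0.33 log units; beyond the scatter), giving an estimated 2800 nM with a likely range from 1100 nM to 7000 nM.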

Compound 3, inhibition constant: 147 nM
Compound 3: the middle estimate sits 19-fold (1.28 log units) above what was measured; the whole stated range lies above it.
By their numbers in this assay, from the lowest: compound 3; then compound 1; then compound 2.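

In this assay the effect of a methyl on this chain carbon does not keep its direction: turning ethyl into isopropyl raised the number, but turning isopropyl into tert-butyl gives an 8.8-fold lower number from compound 2 to compound 3 (0.95 log units; beyond the scatter) and more than recovers that loss. Tert-butyl also compares well with ethyl directly, with a 3.7-fold lower number from compound 1 to compound 3 (0.57 log units; beyond the scatter), so across these three compounds the number does not follow the count of methyls added, and one step at this position does not predict the next. No measurement shown here accounts for this reversal.

As far as these compounds go, whether binding keeps improving with a still larger group on the ring amine, such as cyclohexyl or benzyl, remains open. So does whether the tert-butyl gain would hold with a longer chain in place of the one carrying the ring amine.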